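This account rests on a few compounds, and the source may have more. Where it says the series, first, only, none or still open, it means among the compounds named here.

Measured so far in a functional assay on MCF7 cells (Homo sapiens) for antiproliferative activity, read by MTT assay, with a stated time of 72 h; on this read-out lower numbers stand for stronger inhibition and higher numbers for weaker inhibition:

Compound 1, `COc1ccc2oc(CSC(=S)N(C(C)C)C(C)C)cc(=O)c2c1`: in this assay compound 1 gives > 25000 nM, which is a limit of the assay rather than a number.
Compound 2, `COc1ccc2oc(CSC(=S)N3CCCCC3)cc(=O)c2c1`: in this assay compound 2 gives 10000 nM.
Compound 3, `O=c1cc(CSC(=S)N2CCOCC2)oc2ccccc12`: in this assay compound 3 gives 21000 nM.

Of the two actual numbers, compound 3 stands highest, so it is the weaker inhibitor of the pair; the nearer value belongs to compound 2, and the two lie beyond the usual scatter of each other. Within the data shown here, the only step measured between compounds that differ in one place is an at least 2.5-fold lower number from compound 1 to compound 2 (0.39 log units; beyond the scatter); it concerns the amine attached to the thiocarbonyl carbon and not the aromatic ring.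

The compound still to be measured is compound 4, `COc1ccc2oc(CSC(=S)N3CCOCC3)cc(=O)c2c1`. It differs from compound 3 by methoxy in place of hydrogen on an aromatic carbon. Among the measured compounds shown here, compounds 1 and 2 carry a methoxy at that place as well, but no measured pair isolates this single change, so no measured step bears directly on it. Without such evidence, no step beyond the scatter is expected, and the step of no change at the digits printed from compound 3 to compound 4 (within the scatter) is what the estimate for compound 4 means. Compound 4 is therefore estimated at 21000 nM, with a range from 8000 nM to 50000 nM.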

Compound 4, half-maximal inhibitory concentration: > 25000 nM
Compound 4: no number, only a limit; the forecaster's own chance of this, stated with the estimate: 25%; middle value at least 1.1-fold (0.07 log units) from the limit.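

Methoxy in place of hydrogen, on the six-membered aromatic ring, meta to a fused ring and para to a fused ring, did not lower the number in this assay when morpholin-4-yl is the amine; the data give an at least 1.1-fold higher number from compound 3 to compound 4 (0.07 log units; that floor lies within the scatter), so how much the number rises, if it really rises, stays unknown. With the methoxy held the same, the amine can now be compared directly, and the result is an at least 2.5-fold higher number from compound 2 to compound 4 (0.39 log units; beyond the scatter), which means that morpholin-4-yl, like diisopropylamino, gives weaker inhibition than piperidin-1-yl. Compound 4 gives > 25000 nM, which is a limit of the assay and not a number, and the step between compound 1 and compound 4 cannot be read: the limit of > 25000 nM in this assay, at which 2 of the 4 values shown sit.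

The compounds shown leave open whether methoxy in place of hydrogen changes the number when piperidin-1-yl is the amine, a question that would need the partner of compound 2 with hydrogen at this place. Also open, from the compounds shown here alone, is whether a hydroxyl group or a chlorine atom at this place, or piperazin-1-yl in place of the amine, would bring stronger inhibition.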